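Halogen swap on the shared core of compound 1

A few compounds are considered here, and "the series" means these few. Any claim that something is new, unique, unknown or untested is made for them only; others in the source may bear on it.

The series shares a core carrying a (2-hydroxyethoxy)methyl group, and three members have been run in a functional assay on KB cells (Homo sapiens) for inhibition; a lower number here means a stronger inhibitor, a higher number a weaker inhibitor. Compound 1 `OCCOCn1c(Cl)nc2cc(Cl)c(Cl)cc21` reaches only a limit there: in this assay compound 1 gives > 320000 nM, a limit of the assay and not a number. Compound 2 `OCCOCn1cnc2c(Cl)cc(Cl)cc21` likewise gives a limit, > 100000 nM. Compound 3 `OCCOCn1c(S)nc2c(Cl)c(Cl)ccc21` also gives a limit, > 100000 nM. Within the data shown here, no measured pair differs in a single place, so no measured step exists; what the values show is that all three sit at a limit, two of them at the limit of > 100000 nM in this assay, at which 2 of the 3 values shown sit, and one at the limit of > 320000 nM in this assay, at which 1 of the 3 values shown sits. Compound 1 therefore cannot be placed against any measured number in this assay: it is known only as a limit.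

Compound 4 `OCCOCn1c(Br)nc2cc(Cl)c(Cl)cc21` differs from compound 1 by bromo in place of chloro on an aromatic carbon. Among the measured compounds shown here, with no measured step to draw on and every measured member at a limit, no step beyond the scatter in either direction is expected in this assay. For compound 4 the estimated step is a number no higher from compound 1 to compound 4 (the limit leaves the size open), of no real size. Compound 4 is thus estimated at 320000 nM, with a range from 100000 nM to 1000000 nM, and the assay is expected most likely to report again only a limit.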

Compound 4, half-maximal inhibitory concentration: > 100000 nM
Compound 4 gave a limit, no number; the forecaster's own chance of this, stated with the estimate: 85%; the middle value does not contradict the limit.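

In this assay compound 4 gives > 100000 nM, a limit and not a number. Compound 1 gives > 320000 nM, also a limit. Among these compounds, no step between compound 1 and compound 4 can be read from these two limits. The compounds shown leave open whether bromo in place of chloro on an aromatic carbon changes inhibition at all.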